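Bromobenzyl isomers in a triazole-linked chalcone series

A few compounds are considered here, and "the series" means these few. Any claim that something is new, unique, unknown or untested is made for them only; others in the source may bear on it.

Compound 1, `COc1ccc(C(=O)/C=C/c2ccc(OCc3cn(Cc4ccccc4Br)nn3)cc2)cc1`, gives 60%.
Compound 2, `COc1ccc(C(=O)/C=C/c2ccc(OCc3cn(Cc4cccc(Br)c4)nn3)cc2)cc1`, gives 45%.
Compound 3, `O=C(/C=C/c1ccc(OCc2cn(Cc3ccccc3Br)nn2)cc1)c1ccc([N+](=O)[O-])cc1`, gives 43%.

These three compounds were tested in a functional assay on MCF7 cells (Homo sapiens) for inhibition, read by MTT assay, with a stated time of 48 h, tested at 10 uM; a lower number here means less inhibition of growth, a higher number more inhibition of growth at the concentration tested. Compound 1 and compound 2 share one core and differ by 3-bromophenyl in place of 2-bromophenyl on a saturated chain carbon bound to an aromatic nitrogen; that change gave a number 15 percentage points lower from compound 1 to compound 2 (beyond the scatter). Compound 3 carries a different core, which differs from that of compound 1 by nitro in place of methoxy on an aromatic carbon; this change gave a number 17 percentage points lower from compound 1 to compound 3 (beyond the scatter). Compound 2 and compound 3 show values within the scatter of each other.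

Compound 4, `O=C(/C=C/c1ccc(OCc2cn(Cc3cccc(Br)c3)nn2)cc1)c1ccc([N+](=O)[O-])cc1`, has not yet been measured. It differs from compound 3 by 3-bromophenyl in place of 2-bromophenyl on a saturated chain carbon bound to an aromatic nitrogen, the same change as that between compound 1 and compound 2, made on the same place. Because compound 1 to compound 2 gave a number 15 percentage points lower from compound 1 to compound 2 (beyond the scatter), a step of similar direction is expected for compound 4, a number 13 percentage points lower from compound 3 to compound 4 (beyond the scatter), though this rests on a single earlier pair and on a different core. On that basis compound 4 is estimated at 30%, with a range from 15% to 45%.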

Compound 4, percent growth inhibition at one concentration: 12%
Compound 4: middle estimate off by 18 percentage points, on the high side; the measured number lies below the stated range.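

In this assay, the change from 2-bromobenzyl to 3-bromobenzyl kept its direction on the second core but not its size, giving a number 31 percentage points lower from compound 3 to compound 4 (beyond the scatter), and the two steps differ: the same change on two cores in this assay, a number 15 percentage points lower (beyond the scatter) from compound 1 to compound 2 and a number 31 percentage points lower (beyond the scatter) from compound 3 to compound 4, 16 percentage points apart, beyond the scatter of two such steps. Nitro in place of methoxy likewise kept its direction but not its size when carried from the 2-bromobenzyl pair to the 3-bromobenzyl pair, giving a number 33 percentage points lower from compound 2 to compound 4 (beyond the scatter): the same change on two cores in this assay, a number 17 percentage points lower (beyond the scatter) from compound 1 to compound 3 and a number 33 percentage points lower (beyond the scatter) from compound 2 to compound 4, 16 percentage points apart, beyond the scatter of two such steps. These two gaps are one observation read two ways from the same four compounds, so they show that the direction of each change carried over while its size did not, but they do not show what causes the difference or whether it extends beyond these compounds.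

The compounds shown leave open how the bromobenzyl change behaves with an amine or a carboxylic acid in the place held by methoxy and nitro. They also leave open whether chlorine in the place of bromine would give steps of the same size.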